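The source may report more compounds than this note shows. Statements on the series, on what has been measured and on what is new or still open speak of the compounds shown alone.

The measured compounds:
Compound 1, `CC(C)COc1ncc(-c2cc(F)c(-c3nnc(S(=O)(=O)CC4CC4)[nH]3)cc2F)cc1Cl`, gives 58 uL/min in an ADME assay on microsomes from liver (Rattus norvegicus) for metabolic stability; a higher number here means faster removal of the compound, a lower number slower removal.
Compound 2, `O=S(=O)(CC1CC1)c1nnc(-c2cc(F)c(-c3cnc(Oc4ccccc4C(F)(F)F)c(Cl)c3)cc2F)[nH]1`, gives < 14 uL/min in this assay, and this reading is a limit of the assay rather than a number.
Compound 3, `CC(C)COc1ncc(-c2cc(F)c(-c3nnc(S(C)(=O)=O)[nH]3)cc2F)cc1Cl`, gives 23 uL/min in this assay.

Of the three values, compound 2 alone sits at the limit of < 14 uL/min in this assay, at which 1 of the 3 values shown sits, so its position among the numbers is known only as a bound. The piece now turns to compound 4, `O=S(=O)(CC1CC1)c1nnc(-c2cc(F)c(-c3cnc(Oc4ccc(F)cc4Cl)c(Cl)c3)cc2F)[nH]1`, which has not yet been measured in this assay. Compared with compound 2, the change is 2-chloro-4-fluorophenyl in place of 2-(trifluoromethyl)phenyl on an oxygen on an aromatic ring.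

Two measured steps exist. The step of an at least 4.1-fold lower number from compound 1 to compound 2 (0.61 log units; beyond the scatter) shows that placing an aromatic group on that oxygen took the number down to the limit. The step of a 2.5-fold lower number from compound 1 to compound 3 (0.40 log units; beyond the scatter) concerns a different part of the molecule and does not bear on the present change. For the measured compounds named here, no measured pair shows a swap of one aromatic group for another on that oxygen, so the expectation rests on compound 2 alone: compound 4 keeps an aromatic group there, and its number is expected to remain close to compound 2, with a step that the limit leaves unreadable from compound 2 to compound 4, inside the scatter. Compound 4 is therefore estimated at 12 uL/min, between 6 uL/min and 28 uL/min.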

Compound 4, intrinsic clearance in a liver preparation (reported as CLH), per the amount of preparation that the assay uses: 53 uL/min
Compound 4: middle estimate off by 4.4-fold (0.65 log units), on the low side; the measured number lies above the stated range.
By their numbers in this assay, from the lowest: compound 3; then compounds 4 and 1 (each within the scatter of the next). At a limit, below all of these: compound 2.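

In this assay, the earlier picture of an aromatic group on that oxygen holding the number down turns out to depend on which aromatic group it is, and compound 4 goes against it: 2-chloro-4-fluorophenyl in place of 2-(trifluoromethyl)phenyl gives an at least 3.7-fold higher number from compound 2 to compound 4 (0.57 log units; beyond the scatter). Set against the isobutyl group on the same oxygen, 2-chloro-4-fluorophenyl gives a 1.1-fold lower number from compound 1 to compound 4 (0.04 log units; within the scatter), so these two groups, one aromatic and one a saturated chain, are not told apart in this assay, and only 2-(trifluoromethyl)phenyl of the three stands apart from the others. The reading of compound 2 is a limit and not a number, so the step from it has a known bound but no known size: the limit of < 14 uL/min in this assay, at which 1 of the 4 values shown sits.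

The compounds shown do not separate the parts of the change, leaving open whether the loss of trifluoromethyl, the chlorine or the fluorine accounts for the step. They also leave open how this assay would read with a nitrile or an amine on the aromatic group, or with a longer chain in place of isobutyl on that oxygen.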